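A few compounds are considered here, and "the series" means these few. Any claim that something is new, unique, unknown or untested is made for them only; others in the source may bear on it.

Measured compounds:
compound 1 `COc1cccc(/C=C/C(=O)c2ccc(OC)c3c2OC(C)(C)C=C3)c1`: 9360 nM
compound 2 `COc1ccc(C(=O)/C=C/c2ccc3ccccc3c2)c2c1C=CC(C)(C)O2`: 7650 nM

In a functional assay on SK-OV-3 cells (Homo sapiens) for antiproliferative activity, read by MTT assay, with a stated time of 24 h (on this read-out lower numbers stand for stronger inhibition and higher numbers for weaker inhibition), compound 1 gives 9360 nM, and compound 2 gives 7650 nM. These two numbers lie within the scatter of each other, so neither compound can be called the weaker. Compound 3 `COc1ccc(C(=O)/C=C/c2cccc([N+](=O)[O-])c2)c2c1C=CC(C)(C)O2` differs from compound 1 in one place: nitro in place of methoxy on an aromatic carbon. Within the data shown here, no measured pair shows what this swap does, so the step from compound 1 to compound 3 is expected to stay within the usual scatter, in no firm direction. The estimated step of a 1.2-fold lower number from compound 1 to compound 3 (0.10 log units; within the scatter) reflects that. Compound 3 is expected to give 7500 nM, within a range from 2500 nM to 22000 nM.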

Compound 3, half-maximal inhibitory concentration: 9720 nM
The estimate for compound 3 lay 1.3-fold (0.11 log units) below the measured number, and the stated range covers the measured number.
By their numbers in this assay, from the lowest: compounds 2, 1 and 3 (each within the scatter of the next).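

The change from 3-methoxyphenyl to 3-nitrophenyl gives a 1.0-fold higher number from compound 1 to compound 3 (0.02 log units; within the scatter) in this assay. This first measured pair for the swap shows that, on this shared core, nitro can stand in place of methoxy at this position with no readable change in the number. Nothing measured here offers an explanation for this result. Still open, on these data alone, is whether an amine, a carboxylic acid or a longer alkoxy chain at the same position would move the number beyond the scatter.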